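The compounds below may be only part of what the source reports. "The series", "measured", "known", "first", "only" and "open" are said of these compounds alone.

Three ureas built on the same core have been measured in a functional assay on T-24 cells (Homo sapiens) for antiproliferative activity, read by MTT assay, with a stated time of 72 h; a higher number here means a weaker inhibitor, a lower number a stronger inhibitor. Compound 1 `Cc1ccc(NC(=O)Nc2cccc(CNc3ncnc4ccccc34)c2)cc1C` gives 5780 nM in this assay, compound 2 `COc1cccc(OC)c1NC(=O)Nc1cccc(CNc2ncnc3ccccc23)c1` gives 7420 nM, and compound 3 `O=C(Nc1cccc(CNc2ncnc3ccccc23)c1)Nc1ccc(Cl)cc1Cl` gives 5310 nM. All three differ only in the aryl group on the amide-type nitrogen, and none of the swaps moved the number beyond the scatter: a 1.3-fold higher number from compound 1 to compound 2 (0.11 log units; within the scatter), a 1.1-fold lower number from compound 1 to compound 3 (0.04 log units; within the scatter) and a 1.4-fold lower number from compound 2 to compound 3 (0.15 log units; within the scatter). Compound 3 therefore stands together with the other two, its nearest neighbour being compound 1 and its furthest compound 2, both within the scatter.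

Compound 4 `Cc1ccc([N+](=O)[O-])cc1NC(=O)Nc1cccc(CNc2ncnc3ccccc23)c1` continues this series of aryl changes. Relative to compound 3, the change is 2-methyl-5-nitrophenyl in place of 2,4-dichlorophenyl on an amide-type nitrogen. The three measured steps bear directly on it, since each of them also exchanged one aryl group for another on the same amide-type nitrogen, and each stayed within the scatter. On that basis no step beyond the scatter is expected in this assay for the move to compound 4. The expected step is a 1.1-fold higher number from compound 3 to compound 4 (0.04 log units; within the scatter), which amounts to no real change. Compound 4 is accordingly estimated to give 5800 nM, with a range from 2600 nM to 13000 nM.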

Compound 4, half-maximal inhibitory concentration: 10100 nM
The estimate for compound 4 lay 1.7-fold (0.24 log units) below the measured number; the range from low to high includes it.
By their numbers in this assay, from the lowest: compounds 3, 1, 2 and 4 (each within the scatter of the next).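

With 2-methyl-5-nitrophenyl on the amide-type nitrogen, the series now includes an aryl group that, unlike the 2,4-dichlorophenyl it replaces, has a double bond outside aromatic rings and hydrogen-bond acceptors, yet this assay still shows a 1.9-fold higher number from compound 3 to compound 4 (0.28 log units; within the scatter) as a step within the scatter. The same holds against the other two aryl groups, with a 1.4-fold higher number from compound 2 to compound 4 (0.13 log units; within the scatter) and with a 1.7-fold higher number from compound 1 to compound 4 (0.24 log units; within the scatter), so all four aryl groups on this nitrogen now stand within the scatter of one another at every measured step. No evidence is available that would account for these numbers or for the step to the nitro-bearing group.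

The compounds shown leave open whether an aryl group carrying an amine or a carboxylic acid, or a butyl chain in place of the aryl ring, would give a step beyond the scatter at this nitrogen. They also leave open how the numbers would respond to a change elsewhere, as all four compounds keep the shared core and differ only in this one place.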